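A few compounds are considered here, and "the series" means these few. Any claim that something is new, unique, unknown or untested is made for them only; others in the source may bear on it.

The measured compounds:
compound 3 `CC1=NC(c2cn(S(=O)(=O)c3ccccc3C)c3ccc(C)cc23)CN1` gives 1300 nM in an assay on isolated protein for inhibition of kallikrein-7 (Mus musculus), read by fluorescence, with stated times of 10 min and 30 min; a lower number here means a stronger inhibitor, a higher number a weaker inhibitor.
compound 2 `CC1=NC(c2cn(S(=O)(=O)c3ccccc3F)c3ccc(C)cc23)CN1` gives 6400 nM in this assay.
compound 1 `CC1=NC(c2cn(S(=O)(=O)c3ccc(F)cc3)c3ccc(C)cc23)CN1` reaches only a limit of this assay, > 30000 nM.

Compound 3 holds the lowest of the two numbers given, its nearest neighbour being compound 2 (a 4.9-fold lower number from compound 2 to compound 3 (0.69 log units; beyond the scatter)); compound 1 sits at a limit (the limit of > 30000 nM in this assay, at which 1 of the 3 values shown sits). Compound 4 `CC1=NC(c2cn(S(=O)(=O)c3ccccc3C#N)c3ccc(C)cc23)CN1` differs from compound 3 by cyano in place of methyl on an aromatic carbon. Among the compounds with values here, two measured steps bear on this: an at least 23-fold lower number from compound 1 to compound 3 (1.36 log units; beyond the scatter) and an at least 4.6-fold lower number from compound 1 to compound 2 (0.67 log units; beyond the scatter) show that moving a substituent to the position ortho to the large group lowers the number, and a 4.9-fold lower number from compound 2 to compound 3 (0.69 log units; beyond the scatter) shows that the identity of that substituent also matters. Within the data shown here, no measured compound carries a cyano group, so the direction of the change from methyl to cyano rests on no direct comparison. A modest rise in the number is therefore expected for compound 4, a 1.9-fold higher number from compound 3 to compound 4 (0.28 log units; within the scatter), with wide uncertainty. Compound 4 is estimated at 2500 nM, with a range from 600 nM to 12000 nM.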

Compound 4, half-maximal inhibitory concentration: 11000 nM
For compound 4 the middle estimate is 4.4-fold (0.64 log units) below the measured one; low and high end bracket the measured number.
By their numbers in this assay, from the lowest: compound 3; then compounds 2 and 4 (each within the scatter of the next). At a limit, above all of these: compound 1.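

Cyano in place of methyl on an aromatic carbon, ortho to a large group, gives an 8.5-fold higher number from compound 3 to compound 4 (0.93 log units; beyond the scatter) in this assay, which shows that this place distinguishes between small groups and that methyl is preferred over cyano here. Cyano in place of fluoro gives a 1.7-fold higher number from compound 2 to compound 4 (0.24 log units; within the scatter), so these two groups cannot be told apart at this place, while methyl stands clear of both. The 2-cyanophenyl group in place of 4-fluorophenyl gives an at least 2.7-fold lower number from compound 1 to compound 4 (0.43 log units; beyond the scatter), which is only a bound, as compound 1 stands at a limit: the limit of > 30000 nM in this assay, at which 1 of the 4 values shown sits.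

The compounds shown leave open whether ethyl, chloro or methoxy at this place would match or pass methyl, and how an amine or a carboxylic acid would fare there. They also leave open whether methyl and cyano keep this order when the rest of the shared core changes.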